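The source may hold more compounds than are shown below. What is called first, only, known or untested is meant among the compounds shown, and "the series" means these compounds.

Values in a functional assay on HepG2 cells (Homo sapiens) for inhibition, read by MTT assay, with a stated time of 24 h; on this read-out higher numbers stand for weaker inhibition and lower numbers for stronger inhibition:
- compound 1 `O=[N+]([O-])c1cc(Cl)ccc1CNc1cc(C(F)(F)F)cc2[nH]ncc12` gives 5820 nM
- compound 2 `O=[N+]([O-])c1ccc(Cl)cc1CNc1cc(C(F)(F)F)cc2[nH]ncc12` gives 1300 nM

Compound 2 holds the lower of the two numbers, and compound 1 is its nearest neighbour, with a gap beyond the scatter. The next entry is compound 3 `O=[N+]([O-])c1ccccc1CNc1cc(C(F)(F)F)cc2[nH]ncc12`, which differs from compound 2 as follows: hydrogen in place of chloro on an aromatic carbon. In words, hydrogen stands in place of chloro on an aromatic carbon, para to a nitro group.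

Going by the values given here, no measured step isolates this change, so the expectation is loose. Compound 1 and compound 2 both carry a chloro yet lie apart, so the two values give no single reading for its removal. A moderate move in this assay towards weaker inhibition is expected, with no change beyond the scatter also possible. The expected step is a 2.2-fold higher number from compound 2 to compound 3 (0.33 log units; beyond the scatter) on this estimate. For compound 3 the estimated value is 2800 nM with an expected range from 1000 nM to 8000 nM in this read-out.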

Compound 3, half-maximal inhibitory concentration: 7760 nM
For compound 3 the middle estimate is 2.8-fold (0.44 log units) below the measured one, within the range that was stated.
By their numbers in this assay, from the lowest: compound 2; then compounds 1 and 3 (each within the scatter of the next).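

In this assay, going by these compounds alone, compound 3 gives the first hydrogen counterpart for the chloro para to a nitro group, and the result is a 6.0-fold higher number from compound 2 to compound 3 (0.78 log units; beyond the scatter) in a modest step beyond the scatter, so chloro at this position goes with stronger inhibition than hydrogen. The chloro of compound 1, at its other place on the ring, does not separate from hydrogen: a 1.3-fold higher number from compound 1 to compound 3 (0.12 log units; within the scatter) is the reading, so among these three compounds the advantage belongs to chloro at the place it holds in compound 2, not to chloro anywhere on this ring. No measurement on hand accounts for this difference between the two chloro placements.

As far as these compounds go, it remains open whether chloro itself is needed at this position, since a fluoro, a bromo, a methyl or a methoxy group there would separate the atom from the mere presence of a substituent. The shown compounds also all keep the nitro and trifluoromethyl groups, so the effect of replacing the nitro with an amine or a nitrile on this chloro step stays unknown.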